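The compounds below may be only part of what the source reports. "The series", "measured", "known", "first", "only" and "open" are said of these compounds alone.

Measured in a functional assay on CAKI-1 cells (Homo sapiens) for cytotoxicity, read by sulforhodamine B assay, with a stated time of 48 h; a lower number here means a stronger inhibitor of growth, a higher number a weaker inhibitor of growth:
compound 1, `CC1=C(C(=O)Nc2ccc(F)c(Cl)c2)C(c2cccc(O)c2)NC(=S)N1`: compound 1 gives 50100 nM
compound 2, `CC1=C(C(=O)Nc2ccc(F)c(Cl)c2)C(c2cccc(Oc3ccccc3)c2)NC(=O)N1`: compound 2 gives 10000 nM
compound 3, `CC1=C(C(=O)Nc2ccc(F)c(Cl)c2)C(c2ccccc2Cl)NC(=S)N1`: compound 3 gives 31600 nM

Compound 3 stands second highest of the three numbers in this assay. Within the data shown here, its nearest neighbour is compound 1, and the single step between them, a 1.6-fold lower number from compound 1 to compound 3 (0.20 log units; within the scatter), lies within the scatter. Among the measured compounds shown here, compound 2 sits furthest away; it differs from compound 3 in more than one place, so no single step is drawn, and its value simply shows a lower number than that of compound 3.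

Compound 4, `CC1=C(C(=O)Nc2ccc(F)c(Cl)c2)C(c2cccc(Cl)c2)NC(=S)N1`, is not yet measured. It differs from compound 3 by 3-chlorophenyl in place of 2-chlorophenyl on a saturated ring carbon. For the measured compounds named here, the only measured step that touches this saturated ring carbon is a 1.6-fold lower number from compound 1 to compound 3 (0.20 log units; within the scatter), where a much larger exchange of the aryl group produced no change beyond the scatter. Going by the values given here, no measured pair shows the same atoms joined differently on this carbon, so there is nothing to suggest a step in either direction.

On that basis compound 4 is expected to give about 30000 nM in this assay, with a plausible range from 12000 nM to 80000 nM. The expected step, a 1.1-fold lower number from compound 3 to compound 4 (0.02 log units; within the scatter), is therefore estimated to fall within the scatter.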

Compound 4, concentration for 50% growth inhibition: 39800 nM
Compound 4: middle estimate off by 1.3-fold (0.12 log units), on the low side, within the range that was stated.
By their numbers in this assay, from the lowest: compound 2; then compounds 3, 4 and 1 (each within the scatter of the next).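

In this assay, the exchange of 2-chlorophenyl for 3-chlorophenyl on the saturated ring carbon (a 1.3-fold higher number from compound 3 to compound 4 (0.10 log units; within the scatter)) shows that, for this one pair, joining the same atoms differently leaves the two numbers indistinguishable. Compound 4 also separates what the earlier step from compound 1 to compound 3 had combined, since chloro in place of hydroxy on an aromatic carbon can now be read alone (a 1.3-fold lower number from compound 1 to compound 4 (0.10 log units; within the scatter)), and this exchange too gives numbers that cannot be told apart. No measurement is available that would explain why these compounds sit so close together.

The compounds shown leave open whether a different group on the aryl ring, such as an amine or a carboxylic acid, would give a step beyond the scatter. They also leave open what lies behind the lower number of compound 2 (10000 nM), which carries a phenoxy group and a carbonyl where compounds 1, 3 and 4 have other groups, so neither of the two can be assessed alone.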